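The source may report more compounds than this note shows. Statements on the series, on what has been measured and on what is new or still open speak of the compounds shown alone.

In an ADME assay on Vero cells (Chlorocebus sabaeus) for cytotoxicity, read by MTT assay, with a stated time of 72 h (on this read-out higher numbers stand for lower toxicity in this test and lower numbers for higher toxicity in this test), compound 2 `COC(=O)c1cc(-c2cccc(NC(=O)c3ccc(/C=C/C(=O)c4cc(F)ccc4F)cc3)c2)on1` is known only as a limit, > 40 ug/mL, the same kind of limit described in the limit of > 40 ug/mL in this assay, at which 1 of the 3 values shown sits. Compound 1 `COC(=O)c1cc(-c2cccc(NC(=O)c3ccc(OCc4ccc(Cl)cc4)cc3)c2)on1` also stops at a limit in this assay, > 80 ug/mL, as stated in the limit of > 80 ug/mL in this assay, at which 1 of the 3 values shown sits. Compound 3 `CC(C)Cc1ccc(C(=O)/C=C/c2ccc(C(=O)O)cc2)cc1`, a smaller molecule without the shared core, gives a limit at the other end, < 10 ug/mL, as noted in the limit of < 10 ug/mL in this assay, at which 1 of the 3 values shown sits. The only one-place step among these, a step that the two limits leave unreadable from compound 1 to compound 2, cannot be read as a size, so no measured step bears directly on the next change. Compound 4 `CCOc1ccc(C(=O)/C=C/c2ccc(C(=O)Nc3cccc(-c4cc(C(=O)OC)no4)c3)cc2)cc1` differs from compound 2 by 4-ethoxyphenyl in place of 2,5-difluorophenyl on a carbonyl carbon. With compound 2 sitting at a limit and compound 1 at a higher limit, the step that the limit leaves unreadable from compound 2 to compound 4 is expected to stay within the scatter, and compound 4 is estimated at 50 ug/mL in this assay, with a likely range from 20 ug/mL to 100 ug/mL, quite possibly reported again only as a limit.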

Compound 4, half-maximal cytotoxic concentration: > 40 ug/mL
Compound 4: no number, only a limit (the forecaster's own chance of this, stated with the estimate: 60%); the middle value lies beyond the limit too.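

Compound 2 and compound 4 are both known only as limits in this assay, so the size of the step between them cannot be read. The compounds shown leave open whether 4-ethoxyphenyl in place of 2,5-difluorophenyl on a carbonyl carbon changes the read-out at all.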